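The source may report more compounds than this note shows. Statements on the series, on what has been measured and on what is new or still open speak of the compounds shown alone.

Compound 1 `Cc1ccccc1-c1nnc(SCCn2c([N+](=O)[O-])cnc2C)o1` is the reference point of the series. In a functional assay on HepG2 cells (Homo sapiens) for cytotoxicity, read by MTT assay, with a stated time of 48 h (on this read-out higher numbers stand for weaker inhibition and lower numbers for stronger inhibition), compound 1 gives 5100 nM, the lowest of the two numbers recorded, with compound 2 `COc1ccccc1-c1nnc(SCCn2c([N+](=O)[O-])cnc2C)o1` the nearest neighbour. In this assay compound 2 gives 10000 nM; the step of a 2.0-fold higher number from compound 1 to compound 2 (0.29 log units; within the scatter) shows that exchanging one aromatic substituent on the phenyl ring for another left the read-out essentially unchanged. Compound 3 `Cc1ncc([N+](=O)[O-])n1CCSc1nnc(-c2ccc(F)cc2)o1` is not yet measured. It differs from compound 1 as follows: 4-fluorophenyl in place of 2-methylphenyl on an aromatic carbon. No measured step covers this exact exchange; the only comparable one, the step from compound 1 to compound 2, was within the scatter, which gives no reason to expect a shift beyond it here either. On that basis compound 3 is expected to give about 6000 nM in this assay, with a plausible range of 2500 nM to 15000 nM. The step implied by this estimate is a 1.2-fold higher number from compound 1 to compound 3 (0.07 log units; within the scatter).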

Compound 3, half-maximal inhibitory concentration: 600 nM
Compound 3: middle estimate off by 10-fold (1.00 log units), on the high side; the measured number lies below the stated range.
By their numbers in this assay, from the lowest: compound 3; then compounds 1 and 2 (each within the scatter of the next).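

In this assay this aromatic carbon of the shared core proves sensitive to the group it carries: 4-fluorophenyl in place of 2-methylphenyl gives an 8.5-fold lower number from compound 1 to compound 3 (0.93 log units; beyond the scatter) and marks stronger inhibition, while 4-fluorophenyl in place of 2-methoxyphenyl gives a 17-fold lower number from compound 2 to compound 3 (1.22 log units; beyond the scatter) and points the same way. Among these compounds, the earlier exchange between the two 2-substituted phenyl groups stayed within the scatter, so only this change, which alters both the substituent and its place on the phenyl ring, shows that the read-out can move beyond the scatter at this position. No measurement bearing on the reason for this shift is available.

The compounds shown do not separate the fluorine from the move to the 4-position of the ring. A 2-fluorophenyl, a 4-methylphenyl or an unsubstituted phenyl group would be needed to tell these two apart.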